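The compounds below may be only part of what the source reports. "The series", "measured", "known", "first", "only" and "open" are said of these compounds alone.

Of the compounds shown here, two of a shared core have been measured. Compound 1 `Cc1ccc(-n2cc(-c3ccccc3NS(=O)(=O)c3c[nH]c(=O)[nH]c3=O)nn2)cc1` and compound 2 `Cc1ccccc1-n1cc(-c2cccc(NS(=O)(=O)c3c[nH]c(=O)[nH]c3=O)c2)nn1` were both tested in a functional assay on SGC-7901 cells (Homo sapiens) for antiproliferative activity, read by MTT assay, with a stated time of 24 h; on this read-out lower numbers stand for stronger inhibition and higher numbers for weaker inhibition. In this assay compound 1 gives 6390 nM. In this assay compound 2 gives 9230 nM. Among the compounds with values here, the two numbers lie within the usual scatter of repeated measurements of this kind, so the data do not separate compound 2 from compound 1; compound 2 simply sits in the same weak range, and no step between the two is recorded, since they differ in more than one place.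

The step that follows leads from compound 2 to compound 3 `O=c1[nH]cc(S(=O)(=O)Nc2cccc(-c3cn(-c4ccc(F)cc4)nn3)c2)c(=O)[nH]1`, which has not yet been measured. The change is 4-fluorophenyl in place of 2-methylphenyl on an aromatic nitrogen of the five-membered aromatic ring with three nitrogens. Within the data shown here, no measured pair shows what such an exchange does on this core, so there is no basis for expecting a step beyond the scatter in either direction. Compound 3 is therefore expected to give about 8000 nM in this assay, within a range from 2500 nM to 25000 nM, which amounts to an expected step of a 1.2-fold lower number from compound 2 to compound 3 (0.06 log units; within the scatter).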

Compound 3, half-maximal inhibitory concentration: > 20000 nM
Compound 3: no number, only a limit; the forecaster's own chance of this, stated with the estimate: 12%; middle value at least 2.5-fold (0.39 log units) away from the limit.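

In this assay, within the data shown here, the exchange of 2-methylphenyl for 4-fluorophenyl on an aromatic nitrogen of the five-membered aromatic ring with three nitrogens gives the only readable step on this core, an at least 2.1-fold higher number from compound 2 to compound 3 (0.33 log units; beyond the scatter). Compound 3 gives a limit of the assay and not a number: the limit of > 20000 nM in this assay, at which 1 of the 3 values shown sits. The step shows that the antiproliferative read-out responds to the group at this position, even though the two groups match in their count of 7 heavy atoms, in having one six-membered aromatic ring of carbon only, in having no hydrogen-bond donors or acceptors, and in carrying no net charge.

The exchange removes the methyl group and brings in fluorine at a different place on the phenyl ring, so the compounds shown cannot tell whether the step follows from the loss of the methyl group, the arrival of the fluorine or the change of place. They also leave open how an unsubstituted phenyl, a 2-fluorophenyl or a 4-methoxyphenyl group on the same nitrogen would read in this assay.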